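This account rests on a few compounds, and the source may have more. Where it says the series, first, only, none or still open, it means among the compounds named here.

Three compounds share one core and differ only in the aryl group on the carbonyl carbon. Compound 1 `COc1cc(C(=O)C2Sc3nnc(-c4cc(OC)c(OC)c(OC)c4)n3NC2c2ccco2)cc(OC)c1OC` carries a 3,4,5-trimethoxyphenyl there and in a functional assay on A549 cells (Homo sapiens) for cytotoxicity, read by MTT assay, with a stated time of 48 h (a higher number here means a weaker inhibitor, a lower number a stronger inhibitor), compound 1 gives 48300 nM. Compound 2 `COc1cc(-c2nnc3n2NC(c2ccco2)C(C(=O)c2cccs2)S3)cc(OC)c1OC` carries a thiophen-2-yl, and in this assay compound 2 gives 78700 nM; the step of a 1.6-fold higher number from compound 1 to compound 2 (0.21 log units; within the scatter) stays within the scatter. Compound 3 `COc1ccc(C(=O)C2Sc3nnc(-c4cc(OC)c(OC)c(OC)c4)n3NC2c2ccco2)cc1` carries a 4-methoxyphenyl. For compound 3 the value in this assay is only a limit, > 100000 nM, so compound 3 stands at the weak end of what was measured, as noted in the limit of > 100000 nM in this assay, at which 1 of the 3 values shown sits. The step of an at least 2.0-fold higher number from compound 1 to compound 3 (0.31 log units; beyond the scatter) is at least modest, while an at least 1.2-fold higher number from compound 2 to compound 3 (0.10 log units; that floor lies within the scatter) has a floor within the scatter.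

Compound 4 `COc1cc(-c2nnc3n2NC(c2ccco2)C(C(=O)c2ccc(O)cc2)S3)cc(OC)c1OC` differs from compound 3 by hydrogen in place of methyl on an oxygen on an aromatic ring. Going by the values given here, no measured step touches this oxygen; the measured steps only exchanged the whole aryl group on the carbonyl carbon and gave small shifts toward weaker inhibition. The author therefore expects the step of a number no higher from compound 3 to compound 4 (the limit leaves the size open) to be no larger than the scatter, in either direction. Compound 4 is estimated in this assay at 100000 nM, with a range from 40000 nM to 300000 nM, and it is expected that compound 4 may again be reported only as a limit.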

Compound 4, half-maximal inhibitory concentration: 93400 nM
Beside the measured number, compound 4's estimate is 1.1-fold (0.03 log units) above it; the range from low to high includes it.
By their numbers in this assay, from the lowest: compounds 1, 2 and 4 (each within the scatter of the next). At a limit, above all of these: compound 3.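

Going by these compounds alone, the step of an at least 1.0-fold lower number from compound 3 to compound 4 (0.02 log units; that floor lies within the scatter) is the first here that alters only the group on an oxygen on an aromatic ring, and not the whole aryl group on the carbonyl carbon. Going by these compounds, its size stays open because compound 3 is recorded only as a limit: the limit of > 100000 nM in this assay, at which 1 of the 4 values shown sits. The measured number for compound 4 does allow firm comparisons, and both a 1.2-fold higher number from compound 2 to compound 4 (0.07 log units; within the scatter) and a 1.9-fold higher number from compound 1 to compound 4 (0.29 log units; within the scatter) leave the 4-hydroxyphenyl, thiophen-2-yl and 3,4,5-trimethoxyphenyl groups indistinguishable on the carbonyl carbon in this assay.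

The compounds shown leave open whether any other group on this aryl ring would move the number beyond the scatter from compound 4. An amine or a carboxylic acid in place of the hydroxy group, or an ethoxy group as a longer chain in place of the methoxy group, would put that question to the test in this assay.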